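The compounds below may be only part of what the source reports. "The series", "measured", "known", "first", "only" and "open" are said of these compounds alone.

Measured compounds:
- compound 1 `CC(C)(C)c1ccc(C(=O)NCc2ccc(-c3nnn[nH]3)cc2)cc1` — 120 nM in an assay on HeLa cells with Bile acid receptor (Homo sapiens) as the target, read by a luciferase reporter, with a stated time of 24 h; on this read-out higher numbers stand for an effect only at larger amounts of compound and lower numbers for an effect already at smaller amounts
- compound 2 `CSc1ccc(CNC(=O)c2ccc(C(C)(C)C)cc2)cc1` — 100 nM in this assay

Among the compounds with values here, compound 2 is one of only two compounds measured so far, and the single step known, a 1.2-fold lower number from compound 1 to compound 2 (0.08 log units; within the scatter), shows that swapping a 1H-tetrazol-5-yl for a methylsulfanyl on the aromatic carbon left the number essentially where it was. Compound 3 `COc1ccc(CNC(=O)c2ccc(C(C)(C)C)cc2)cc1` has not yet been measured. It differs from compound 2 in one place: methoxy in place of methylsulfanyl on an aromatic carbon. Within the data shown here, the only measured step that bears on this position is a 1.2-fold lower number from compound 1 to compound 2 (0.08 log units; within the scatter), and it was within the scatter even though the groups exchanged there differ far more than methylsulfanyl and methoxy do. Among the measured compounds shown here, there is no direct step from methylsulfanyl to methoxy among the measured compounds, so the expectation rests on that single comparison. The step from compound 2 to compound 3 is therefore expected to be small, a 1.5-fold higher number from compound 2 to compound 3 (0.18 log units; within the scatter), with no clear direction beyond the scatter. For compound 3 the expected value in this assay is 150 nM, with a range from 50 nM to 450 nM.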

Compound 3, half-maximal effective concentration: 150 nM
Beside the measured number, compound 3's estimate shows no gap at the digits printed, within the range that was stated.
By their numbers in this assay, from the lowest: compounds 2, 1 and 3 (each within the scatter of the next).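

In this assay, replacing methylsulfanyl with methoxy on the aromatic carbon para to a large group gives a 1.5-fold higher number from compound 2 to compound 3 (0.18 log units; within the scatter) and so adds a second group of the same heavy-atom count, with oxygen where sulfur stood, that cannot be told apart from methylsulfanyl at this position. Within the data shown here, the other new comparison, a 1.3-fold higher number from compound 1 to compound 3 (0.10 log units; within the scatter), shows that methoxy, like methylsulfanyl before it, also cannot be told apart from 1H-tetrazol-5-yl, so the one pair known earlier has grown into a set of three groups, all within the scatter of one another. Nothing at hand explains why these three groups give such similar numbers.

On these data alone, whether any group at this position can move the number beyond the scatter stays open, and a plain hydrogen, an amine, a carboxylic acid or a longer chain such as butoxy would each test that. As far as these compounds go, the rest of the core is identical in all three compounds, so the effect of a change anywhere else in it also remains unknown.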